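The compounds below may be only part of what the source reports. "The series", "measured", "known", "first", "only" and "open" are said of these compounds alone.

Measured so far:
- compound 1, `CNc1nc(NCCCN(C)C)c2sc(-c3ccc(-n4cccn4)cc3)cc2n1`: 1.66 h
- compound 2, `CNc1nc(NCCCN(C)C)c2sc(-c3ccc(OC)nc3)cc2n1`: 3.02 h
- compound 3, `CNc1nc(NCCCN(C)C)c2sc(-c3cccc(C(F)(F)F)c3)cc2n1`: 0.518 h

The three compounds share one core and differ only in the aryl group on it. In an ADME assay (liver) for metabolic stability, with Liver microsome (Homo sapiens) as the target, read by LC-MS, using microsomes, tested at 1 uM (a lower number here means that the compound disappears faster, a higher number that the compound lasts longer), compound 1 gives 1.66 h. Compound 2 gives 3.02 h, which lies within the usual scatter of the number for compound 1, so the two are not told apart here. Among the measured compounds shown here, compound 3 gives 0.518 h, a lower number than compound 1 and beyond the scatter; it is the only compound of the three that stands clearly apart. For the measured compounds named here, no pair differing in a single place has been measured, so no step size is known for this series.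

The next compound, compound 4, `CNc1nc(NCCCN(C)C)c2sc(-c3ccc(S(C)(=O)=O)cc3)cc2n1`, differs from compound 1 in one place: methylsulfonyl in place of 1H-pyrazol-1-yl on an aromatic carbon. The change sits on an aromatic carbon of a six-membered aromatic ring of carbon only, para to a large group. Going by the values given here, with no measured step to lean on, the expectation for this assay is a modest rise in half-life for compound 4 relative to compound 1, of a size that may or may not clear the scatter. The estimated step from compound 1 to compound 4 is a 1.5-fold higher number from compound 1 to compound 4 (0.18 log units; within the scatter). For compound 4 the half-life is estimated at 2.5 h, with a range of 1.2 h to 5 h.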

Compound 4, half-life: 1.92 h
Compound 4: the middle estimate sits 1.3-fold (0.11 log units) above what was measured, within the range that was stated.
By their numbers in this assay, from the lowest: compound 3; then compounds 1, 4 and 2 (each within the scatter of the next).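

In this assay the series now has its first pair differing in one place, and it gives a 1.2-fold higher number from compound 1 to compound 4 (0.06 log units; within the scatter) for methylsulfonyl in place of 1H-pyrazol-1-yl on an aromatic carbon, para to a large group. This is also the first step size known for the series, and it does not separate the two groups, although a five-membered aromatic ring with 2 hetero atoms leaves and a group with no ring enters, with the same counts of hydrogen-bond donors and acceptors on both sides. No measured property of either group bears on this result, so the pair gives no reason for it.

A single step cannot show whether this position is generally insensitive, and an amine, a carboxylic acid or a longer chain in place of methylsulfonyl on the same aromatic carbon would test that in this assay. What separates compound 3, at 0.518 h, also stays open, as no compound shown pairs with it in a single place.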